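The source may hold more compounds than are shown below. What is called first, only, known or untested is meant among the compounds shown, and "the series" means these compounds.

For the measured compounds named here, in a physicochemical assay for lipophilicity, using the shake flask method, in phosphate buffer, measured as octanol-water partition, with a stated time of 24 h, at pH 7.4, tested at 100 uM (on this read-out higher numbers stand for higher lipophilicity and lower numbers for lower lipophilicity), compound 1 (`COc1cc(C)c(-c2cccc(COc3ccc(S(=O)(=O)CC(=O)O)cc3)c2)c(C)c1`) gives 2.45 as the only number so far. Compound 2 (`COc1cc(C)c(-c2cccc(COc3ccc4c(c3)SCC4CC(=O)O)c2)c(C)c1`) is recorded as "not determined" (no result reported) and offers no comparison. Compound 3 (`CCCOc1cc(C)c(-c2cccc(COc3ccc(S(=O)(=O)CC(=O)O)cc3)c2)c(C)c1`) carries propoxy where compound 1 carries methoxy (ethyl in place of hydrogen on a saturated chain carbon bound to an oxygen on an aromatic ring), that is, ethyl in place of hydrogen on a saturated chain carbon bound to an oxygen on an aromatic ring. Going by the values given here, no measured step is available, so the expectation rests on the structural change alone. The expected step is a number 0.80 log units higher from compound 1 to compound 3 (beyond the scatter) upward in this assay and beyond the scatter. For compound 3 the estimated value is 3.25 (range 2.8 to 3.7).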

Compound 3, distribution coefficient: 3.58
The estimate for compound 3 lay 0.33 log units below the measured number; low and high end bracket the measured number.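

In this assay, for the compounds shown here, the read-out at this position proves sensitive to the alkoxy chain: methoxy to propoxy gives a number 1.13 log units higher from compound 1 to compound 3 (beyond the scatter) as the first measured step. The change adds only an ethyl, with no ring, no charge and no hydrogen-bond donor or acceptor, yet the step is large. Nothing available accounts for its size.

Open, as far as these compounds go, is whether a longer chain such as butoxy extends the rise or levels off. Also open, from the compounds shown here alone, is how an amine at the end of the chain would shift the read-out.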